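A few compounds are considered here, and "the series" means these few. Any claim that something is new, unique, unknown or untested is made for them only; others in the source may bear on it.

In a functional assay on thoracic aorta (Rattus norvegicus, strain Wistar), with a stated time of 15 min (on this read-out lower numbers stand for an effect already at smaller amounts and higher numbers for an effect only at larger amounts of compound), three compounds have been measured. Compound 1 `CC(C)Oc1ccc(Br)cc1C(C)NC(=O)NS(=O)(=O)c1ccccc1` gives 143000 nM, the highest of the three numbers. Compound 2 `COc1ccc(Br)cc1C(C)NC(=O)NS(=O)(=O)c1ccc(Cl)cc1` gives 80900 nM, which sits within the usual scatter of the number for compound 1, so these two cannot be told apart. Compound 3 `CCOc1ccc(F)cc1C(C)NC(=O)N(C)S(=O)(=O)c1ccc(Cl)cc1` gives 24500 nM, a number that lies clearly beyond the scatter on the lower side relative to compound 1. None of the three measured compounds differ from one another in only one place, so no single structural change has a measured step behind it.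

Compound 4 `CC(NC(=O)NS(=O)(=O)c1ccccc1)c1cc(Br)ccc1OCc1ccccc1` has not yet been measured. It differs from compound 1 in one place: benzyl in place of isopropyl on an oxygen on an aromatic ring. Going by the values given here, no measured pair shows what this swap does in this assay. With nothing pointing either way, the expected step is a 1.2-fold lower number from compound 1 to compound 4 (0.08 log units; within the scatter), nothing beyond the scatter. Compound 4 is therefore expected to give about 120000 nM, with a range from 40000 nM to 360000 nM.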

Compound 4, half-maximal effective concentration: 130000 nM
The estimate for compound 4 lay 1.1-fold (0.03 log units) below the measured number; low and high end bracket the measured number.
By their numbers in this assay, from the lowest: compound 3; then compounds 2, 4 and 1 (each within the scatter of the next).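

In this assay, putting benzyl in place of isopropyl on an oxygen on an aromatic ring gives a 1.1-fold lower number from compound 1 to compound 4 (0.04 log units; within the scatter). This is the only pair shown that differs in one place, so it is the first direct look at what a single change does in this series, and here the change makes no measurable difference. At this position, a group with more heavy atoms and a six-membered aromatic ring of its own reads the same as the smaller, ring-free isopropyl.

Still open, as far as these compounds go, is whether a different kind of group on this oxygen, such as a chain ending in an amine or a carboxylic acid, would shift the number. Nothing measured here explains why isopropyl and benzyl read alike.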